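A hydroxy group enters where compound 2 carries hydrogen

The source may hold more compounds than are shown below. What is called first, only, known or untested is meant among the compounds shown, and "the series" means these compounds.

Among the measured compounds shown here, compound 2 `c1ccc(-c2nc3ncccn3c2NC2CCCCC2)cc1` is the only member of this small set with a number rather than a limit in a toxicity assay on A549 cells (Homo sapiens) for cytotoxicity, read by luminescence and CellTiter-Glo, with a stated time of 48 h (a lower number here means that less compound is tolerated, a higher number that more compound is tolerated), where compound 2 gives 100000 nM. Compound 1 `COc1ccc(-c2nc3ncccn3c2NC2CCCCC2)cc1` differs from compound 2 only by a methoxy in place of a hydrogen on an aromatic carbon. In this assay compound 1 reaches only a limit of the assay, > 100000 nM. The step from compound 1 to compound 2 is therefore a number no higher from compound 1 to compound 2 (the limit leaves the size open). Because one of the two values stops at the limit of > 100000 nM in this assay, at which 1 of the 2 values shown sits, the size of that step cannot be read.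

Compound 3 `Oc1ccccc1-c1nc2ncccn2c1NC1CCCCC1` carries the change (hydroxy in place of hydrogen on an aromatic carbon). For the measured compounds named here, no measured step repeats this change; the only step available, from compound 1 to compound 2, concerns a different group and its size is not readable. The step expected in this assay is no change at the digits printed from compound 2 to compound 3 (within the scatter), that is, no change beyond the scatter. Compound 3 is estimated to give 100000 nM in this assay, within a range from 40000 nM to 250000 nM.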

Compound 3, half-maximal cytotoxic concentration: > 100000 nM
Compound 3: only a limit was reported; the forecaster's own chance of this, stated with the estimate: 50%; the middle value lies on the limit itself.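

In this assay compound 3 gives > 100000 nM, which is a limit of the assay and not a number. Hydroxy in place of hydrogen on this aromatic carbon, ortho to a large group, gives a number no lower from compound 2 to compound 3 (the limit leaves the size open), so the set now holds a change on the phenyl at this position that brings no lower number, alongside the methoxy of compound 1. The size of neither new step can be read, because the values sit at the limit: the limit of > 100000 nM in this assay, at which 2 of the 3 values shown sit.

The compounds shown leave open whether an amine or a carboxylic acid on this aromatic carbon would bring a number below that limit. They also leave open whether hydroxy elsewhere on this six-membered ring would read the same.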